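Aryl tail variation on the bromoacrylamide series

A few compounds are considered here, and "the series" means these few. Any claim that something is new, unique, unknown or untested is made for them only; others in the source may bear on it.

Measured so far:
compound 1 `C=C(Br)C(=O)Nc1cccc(-c2cn3nc(-c4cccc(OC)c4)sc3n2)c1` gives 580 nM in a functional assay on L1210 cells (Mus musculus) for inhibition, read by cell counting, with a stated time of 2 days; a higher number here means a weaker inhibitor, a lower number a stronger inhibitor
compound 2 `C=C(Br)C(=O)Nc1cccc(-c2cn3nc(CCc4ccccc4)sc3n2)c1` gives 2200 nM in this assay

Within the data shown here, on the two numbers available, compound 2 stands highest; its nearest neighbour is compound 1, and the single measured step between them is a 3.8-fold higher number from compound 1 to compound 2 (0.58 log units; beyond the scatter), a change from a directly attached methoxy-bearing ring to a phenethyl chain.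

Compound 3 `C=C(Br)C(=O)Nc1cccc(-c2cn3nc(Cc4ccc(OC)cc4)sc3n2)c1` is the next member. It differs from compound 2 by 4-methoxyphenyl in place of benzyl on a saturated chain carbon bound to an aromatic carbon. Put the other way, the phenethyl of compound 2 becomes 4-methoxybenzyl: the methoxy-bearing ring comes back, but held one saturated carbon away from the core rather than attached to it as in compound 1, and the chain is shorter than in compound 2.

Among the measured compounds shown here, the only step that bears on this change is a 3.8-fold higher number from compound 1 to compound 2 (0.58 log units; beyond the scatter). Compound 3 sits between the two measured arrangements, so in this assay a modest step back toward compound 1 is expected, a 1.8-fold lower number from compound 2 to compound 3 (0.26 log units; within the scatter), without reaching it. The estimate for compound 3 is 1200 nM, expected within 500 nM to 3000 nM.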

Compound 3, half-maximal inhibitory concentration: 1400 nM
Compound 3: the middle estimate sits 1.2-fold (0.07 log units) below what was measured, and the stated range covers the measured number.
By their numbers in this assay, from the lowest: compound 1; then compounds 3 and 2 (each within the scatter of the next).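

Reading this assay, the step to the 4-methoxybenzyl tail is a 1.6-fold lower number from compound 2 to compound 3 (0.20 log units; within the scatter), so this swap, which shortens the chain and adds a methoxy group together, gives no readable separation of compound 3 from compound 2. The other step, a 2.4-fold higher number from compound 1 to compound 3 (0.38 log units; beyond the scatter), shows that bringing back a methoxy-bearing ring does not by itself recover the number of compound 1 when that ring sits one saturated carbon away from the core; on the three compounds, both tails linked through saturated carbon, in compound 2 and compound 3, give higher numbers than the directly attached 3-methoxyphenyl of compound 1, and none goes against this. Nothing available gives a reason for these differences.

Still open, from the compounds shown here alone, is whether the saturated link or the place of the methoxy group carries the step up from compound 1, as the two change together in that pair; a 3-methoxybenzyl or a directly attached 4-methoxyphenyl tail would separate them. Also open, going by these compounds, is how this position would read with an amine or a carboxylic acid on the tail ring.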